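Two pyridazinone amides, and a halogen-shifted third

The source may hold more compounds than are shown below. What is called first, only, known or untested is meant among the compounds shown, and "the series" means these compounds.

The two measured compounds share one core and differ in the aryl group on the ring nitrogen and in the heteroaryl ether. Compound 1 `O=C(Nc1ccc(Oc2ccnc3[nH]ccc23)cc1)c1nn(-c2ccc(Cl)cc2)ccc1=O` gives 32400 nM in a functional assay on PC-3 cells (Homo sapiens) for cytotoxicity, read by MTT assay, with a stated time of 72 h; on this read-out higher numbers stand for weaker inhibition and lower numbers for stronger inhibition. Compound 2 `Cc1cc(=O)n(-c2cccc(F)c2)nc1C(=O)Nc1ccc(Oc2ncnc3[nH]ccc23)cc1` gives 14600 nM in this assay, the lower of the two numbers; its gap to compound 1 lies beyond the usual scatter of the measurement. Compound 3 `Cc1cc(=O)n(-c2ccc(Br)cc2F)nc1C(=O)Nc1ccc(Oc2ncnc3[nH]ccc23)cc1` is not yet measured. It differs from compound 2 by one change, (4-bromo-2-fluorophenyl in place of 3-fluorophenyl on an aromatic nitrogen), that is, 4-bromo-2-fluorophenyl in place of 3-fluorophenyl on an aromatic nitrogen. Within the data shown here, no measured pair shows what such a change does here, so only a modest step is expected, if any beyond the scatter, and its direction is open. The step from compound 2 to compound 3 is estimated as a 1.5-fold lower number from compound 2 to compound 3 (0.16 log units; within the scatter). Compound 3 is expected to give about 10000 nM, within a range from 3000 nM to 35000 nM.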

Compound 3, half-maximal inhibitory concentration: 2730 nM
The estimate for compound 3 lay 3.7-fold (0.56 log units) above the measured number; the measured number lies below the stated range.
By their numbers in this assay, from the lowest: compound 3; then compound 2; then compound 1.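

Placing 4-bromo-2-fluorophenyl instead of 3-fluorophenyl on the aromatic nitrogen gives a 5.3-fold lower number from compound 2 to compound 3 (0.73 log units; beyond the scatter) in this assay. Among these compounds, this is the first single-place comparison here, and it shows that the number responds to the aryl group at this position. The entering group adds a bromine and also carries its fluorine at a different place on the ring, so this one step cannot separate the two differences, and no measurement on hand explains the result.

Open questions are how a phenyl ring carrying bromine alone would compare, and whether an amine or a methoxy group on that ring would give a similar number. As far as these compounds go, it is also open whether the same swap would lower the number on the core of compound 1.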